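A few compounds are considered here, and "the series" means these few. Any claim that something is new, unique, unknown or untested is made for them only; others in the source may bear on it.

For the measured compounds named here, compound 1 `CCc1ccccc1N(CC(=O)NCc1cccc(OC)c1)S(=O)(=O)c1ccc(C)cc1` is one of two compounds measured in a functional assay on CHO-K1 cells for antagonist activity at prostaglandin E2 receptor EP1 subtype (Homo sapiens), read by FLIPR and calcium flux; a higher number here means a weaker inhibitor, a lower number a stronger inhibitor. In this assay compound 1 gives 138 nM, the lowest of the two numbers; its nearest neighbour is compound 2 `CCc1ccccc1N(CC(=O)NCc1ccc(C(F)(F)F)cc1)S(=O)(=O)c1ccc(C)cc1`, which in this assay gives 209 nM. Going by the values given here, the only step measured between them, a 1.5-fold higher number from compound 1 to compound 2 (0.18 log units; within the scatter), exchanges one aromatic group on the saturated chain carbon bound to the amide-type nitrogen for another and stays within the scatter. Compound 3 `CCc1ccccc1N(CC(=O)NCc1ccccc1F)S(=O)(=O)c1ccc(C)cc1` is not yet measured. It differs from compound 1 at the same place: 2-fluorophenyl in place of 3-methoxyphenyl on a saturated chain carbon bound to an amide-type nitrogen. Among the compounds with values here, the one comparison that bears on this change, a 1.5-fold higher number from compound 1 to compound 2 (0.18 log units; within the scatter), suggests that swapping the aryl group here moves the number little, so a step of no more than the usual scatter is expected, if anything toward a slightly higher number. Compound 3 is therefore expected to give about 180 nM, with a likely range from 70 nM to 450 nM, which would be a step of a 1.3-fold higher number from compound 1 to compound 3 (0.12 log units; within the scatter).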

Compound 3, inhibition constant: 135 nM
The estimate for compound 3 lay 1.3-fold (0.12 log units) above the measured number; measured number inside the range.
By their numbers in this assay, from the lowest: compounds 3, 1 and 2 (each within the scatter of the next).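

In this assay, the step of a 1.0-fold lower number from compound 1 to compound 3 (0.01 log units; within the scatter) and the step of a 1.5-fold lower number from compound 2 to compound 3 (0.19 log units; within the scatter) both lie within the scatter, so three differently substituted aryl groups at this position, on a saturated chain carbon bound to an amide-type nitrogen, cannot be told apart. The new comparison also shows that 2-fluorophenyl, with no hydrogen-bond acceptor counted, can take the place of 3-methoxyphenyl, with one, without a step beyond the scatter. Nothing measured here explains why these groups cannot be told apart. From the compounds shown here alone, whether a carboxylic acid or an amine on this ring, or a longer chain in place of the 2-fluorobenzyl group, would give a step beyond the scatter remains open. The compounds shown also leave open how the number responds to changes elsewhere in the core of compound 1.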